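The source may hold more compounds than are shown below. What is called first, only, known or untested is meant among the compounds shown, and "the series" means these compounds.

Within the data shown here, compound 1 `COc1ccc(CSc2nc(O)c(C)c(Cc3ccc(F)cc3)n2)cc1` is the only member of this pair of measured compounds with a plain number in a functional assay on MT4 cells (Homo sapiens) for cytotoxicity, read by MTT assay (on this read-out higher numbers stand for lower toxicity in this test and lower numbers for higher toxicity in this test), where compound 1 gives 8900 nM. Compound 2 `Cc1c(Cc2c(F)cccc2F)nc(SCc2ccc([N+](=O)[O-])cc2)[nH]c1=O` reaches only a limit of this assay, > 62000 nM. Compound 3 `COc1ccc(CSc2nc(O)c(C)c(Cc3c(F)cccc3F)n2)cc1` is not yet measured. It differs from compound 1 by 2,6-difluorophenyl in place of 4-fluorophenyl on a saturated chain carbon bound to an aromatic carbon. Among the measured compounds shown here, no step between two measured compounds shows what this change does; he expects a small shift toward lower toxicity in this assay, a 1.7-fold higher number from compound 1 to compound 3 (0.23 log units; within the scatter), close to the scatter. For compound 3 he estimates 15000 nM, within 5000 nM to 62000 nM.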

Compound 3, half-maximal cytotoxic concentration: > 64000 nM
Compound 3: a limit, no number (the forecaster's own chance of this, stated with the estimate: 30%); at least 4.2-fold (0.63 log units) between middle value and limit.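

In this assay, among these compounds, 2,6-difluorophenyl in place of 4-fluorophenyl on a saturated chain carbon bound to an aromatic carbon gives an at least 7.1-fold higher number from compound 1 to compound 3 (0.85 log units; beyond the scatter), the first reading of this change, and the step lies beyond the scatter. The value of compound 3 is a limit, not a number: the limit of > 64000 nM in this assay, at which 1 of the 3 values shown sits. Compound 2, which also carries 2,6-difluorophenyl, likewise stands at a limit: the limit of > 62000 nM in this assay, at which 1 of the 3 values shown sits.

On these data alone, how far compound 3 lies past its limit remains open. So does what a plain phenyl or a chlorophenyl group would give at this place.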